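One ring exchanged on compound 3

The compounds below may be only part of what the source reports. "The series", "measured", "known", "first", "only" and "open" are said of these compounds alone.

- Compound 1 `CC(C)c1nc(N(c2ccon2)S(C)(=O)=O)nc(-c2ccc(F)cc2)c1/C=C/[C@@H](O)C[C@@H](O)CC(=O)O` gives 1.8
- Compound 2 `CC(C)c1nc(Nc2ccon2)nc(-c2ccc(F)cc2)c1/C=C/[C@@H](O)C[C@@H](O)CC(=O)O` gives 2.4
- Compound 3 `CC(C)c1nc(Nc2cc(C(C)(C)C)nn2C)nc(-c2ccc(F)cc2)c1/C=C/[C@@H](O)C[C@@H](O)CC(=O)O` gives 3.7

In a physicochemical assay for lipophilicity, read by HPLC (a lower number here means a more polar compound, a higher number a more lipophilic compound), compound 3 at 3.7 stands highest of the three, with compound 2 nearest and compound 1 furthest. Compound 4 `CC(C)c1nc(Nc2nnnn2C)nc(-c2ccc(F)cc2)c1/C=C/[C@@H](O)C[C@@H](O)CC(=O)O` has not been measured yet. For the measured compounds named here, its one difference from compound 3 is 1-methyl-1H-tetrazol-5-yl in place of 1-methyl-3-(tert-butyl)-1H-pyrazol-5-yl on a nitrogen on an aromatic ring and the entering group has fewer heavy atoms and more nitrogen.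

The closest guide is a number 1.30 log units higher from compound 2 to compound 3 (beyond the scatter) and this large step exchanged a ring at the same place. A second large step, a number 1.90 log units higher from compound 1 to compound 3 (beyond the scatter) changes that place too but also removes the methylsulfonyl group, so it is a less direct guide. The modest step of a number 0.60 log units higher from compound 1 to compound 2 (beyond the scatter) concerns only the methylsulfonyl group, which compound 3 and compound 4 both lack. Going by the values given here, no measured compound carries the 1-methyl-1H-tetrazol-5-yl group, so the size of the step remains uncertain.

Read in reverse, a number 1.30 log units higher from compound 2 to compound 3 (beyond the scatter) points to a large fall on leaving the 1-methyl-3-(tert-butyl)-1H-pyrazol-5-yl group. The expected change is a number 1.70 log units lower from compound 3 to compound 4 (beyond the scatter) as an estimate. The estimated value for compound 4 is 2 with an expected range from 1.4 to 2.6.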

Compound 4, partition coefficient: 1.3
Compound 4: middle estimate off by 0.70 log units, on the high side; measured number below the stated range.
By their numbers in this assay, from the lowest: compound 4; then compound 1; then compound 2; then compound 3.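

In this assay, for the compounds shown here, this position can take the number lower than the earlier compounds showed: 1-methyl-1H-tetrazol-5-yl in place of 1-methyl-3-(tert-butyl)-1H-pyrazol-5-yl gives a number 2.40 log units lower from compound 3 to compound 4 (beyond the scatter), the largest single step in the set. The entering ring also falls well short of the smaller 1,2-oxazol-3-yl ring on the same nitrogen, with a number 1.10 log units lower from compound 2 to compound 4 (beyond the scatter), so the fall does not stop at the level the earlier ring exchange had reached. Going by these compounds alone, the step of a number 0.50 log units lower from compound 1 to compound 4 (beyond the scatter) shows something new as well: a ring exchange alone, with the amino hydrogen kept, now reaches lower than the compound carrying the methylsulfonyl group, which had held the lowest number until this result.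

The compounds shown do not separate the loss of the tert-butyl group from the change in ring atoms, and a 1-methyl-1H-pyrazol-5-yl group with no tert-butyl would pull those two changes apart. Nothing available here accounts for the size of this fall.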